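This account rests on a few compounds, and the source may have more. Where it says the series, first, only, none or still open, it means among the compounds named here.

Measured so far in the series:

compound 1 `COc1cc2c(cc1OC)C(CC(=O)Nc1ccccc1)CC2`: 31.3%
compound 2 `COc1cc2c(cc1OC)C(CC(=O)Nc1ccc(Cl)cc1)CC2`: 71.9%

In a functional assay on the whole organism (strain Wistar) for inhibition, with Rattus norvegicus as the target, read by paw edema, with a stated time of 1 h, at a dose of 100 mg/kg (on this read-out higher numbers stand for more inhibition at the one dose given (going by the name of the read-out) and lower numbers for less inhibition), compound 2 stands highest of the two numbers, with compound 1 nearest to it. Going by the values given here, the single step measured, a number 40.6 percentage points higher from compound 1 to compound 2 (beyond the scatter), is the only change in the set so far, and it is large and beyond the scatter.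

The next compound, compound 3 `COc1cc2c(cc1OC)C(CC(=O)Nc1ccccc1C)CC2`, differs from compound 2 by 2-methylphenyl in place of 4-chlorophenyl on an amide-type nitrogen. Among the compounds with values here, no measured step covers this change directly. Within the data shown here, the one step in hand concerns the chlorine: its entry from compound 1 to compound 2 raised the read-out strongly, and in compound 3 that chlorine leaves again, which argues for a number back toward compound 1. Going by these compounds, what the 2-methylphenyl contributes in its place is untested, so the methyl is treated as an open term. The step of a number 29.9 percentage points lower from compound 2 to compound 3 (beyond the scatter) is therefore expected to be downward, though with wide uncertainty. For compound 3 the estimate in this assay is 42%, with a range from 22% to 62%.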

Compound 3, a percentage reported as inhibition, in the whole organism at one dose (the size of the read-out at that dose, not a potency): 21.9%
Compound 3: the middle estimate sits 20.1 percentage points above what was measured, and the stated range ends above it.
By their numbers in this assay, from the lowest: compounds 3 and 1 (each within the scatter of the next); then compound 2.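

In this assay, a number 50 percentage points lower from compound 2 to compound 3 (beyond the scatter), so the high reading does not carry over when 2-methylphenyl replaces 4-chlorophenyl on the amide-type nitrogen. Set against the unsubstituted phenyl compound, the methyl gives a number 9.4 percentage points lower from compound 1 to compound 3 (within the scatter), which leaves compound 3 and compound 1 indistinguishable here and shows that adding a group to this aromatic ring does not by itself reproduce the rise seen with chlorine: among the three compounds, only compound 2 stands apart, and compound 3 goes against any reading that substitution on this ring is enough. Nothing available accounts for either step, and no reason for them can be given from these readings.

The change from compound 2 to compound 3 alters both the group and where it sits on the ring, so the compounds shown leave open whether the high reading of compound 2 follows the chlorine itself or its place. A 4-methylphenyl or a 2-chlorophenyl group on the same nitrogen would separate those two terms, and a 4-fluorophenyl or 4-methoxyphenyl group would show how specific the result is to chlorine.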